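The compounds below may be only part of what the source reports. "The series", "measured", "known", "first", "only" and "open" are said of these compounds alone.

Measured in a functional assay on MCF7 cells (Homo sapiens) for antiproliferative activity, read by MTT assay, with a stated time of 24 h; a higher number here means a weaker inhibitor, a lower number a stronger inhibitor:
- compound 1 `CCn1c(C(=O)NCCO)ccc1C(CC)(CC)c1ccc(OCS(=O)(=O)c2ccccc2)c(C)c1`: 15500 nM
- compound 2 `CCn1c(C(=O)N[C@H](CO)C(C)C)ccc1C(CC)(CC)c1ccc(OCS(=O)(=O)c2ccccc2)c(C)c1`: 25500 nM
- compound 3 `CCn1c(C(=O)NC2(C(=O)O)CC2)ccc1C(CC)(CC)c1ccc(OCS(=O)(=O)c2ccccc2)c(C)c1`: 41200 nM

Compound 3, at 41200 nM, separates clearly from only one of the other two compounds: the data show a 2.7-fold higher number from compound 1 to compound 3 (0.42 log units; beyond the scatter). Its value does not separate from the remaining one, as the data show a 1.6-fold higher number from compound 2 to compound 3 (0.21 log units; within the scatter).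

The next compound, compound 4 `CCn1c(C(=O)N[C@H](C(=O)O)C(C)C)ccc1C(CC)(CC)c1ccc(OCS(=O)(=O)c2ccccc2)c(C)c1`, brings a single change, 1-carboxy-2-methylpropyl in place of 1-carboxycyclopropyl on an amide-type nitrogen.

For the measured compounds named here, two measured steps bear on this change. Compound 2 already carries a 1-(hydroxymethyl)-2-methylpropyl group on that nitrogen, and the step to compound 3 stayed small: a 1.6-fold higher number from compound 2 to compound 3 (0.21 log units; within the scatter). Adding isopropyl to the chain also changed little: a 1.6-fold higher number from compound 1 to compound 2 (0.22 log units; within the scatter). Neither step suggests a clear shift, so no change beyond the scatter is expected.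

The expected step is a 1.2-fold lower number from compound 3 to compound 4 (0.07 log units; within the scatter).

For compound 4 the estimate is 35000 nM, with an expected range from 17000 nM to 70000 nM.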

Compound 4, half-maximal inhibitory concentration: 24500 nM
Estimate against measurement, compound 4: 1.4-fold (0.15 log units) above; the range from low to high includes it.
By their numbers in this assay, from the lowest: compounds 1, 4, 2 and 3 (each within the scatter of the next, the first and the last beyond it).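

In this assay, the open-chain 1-carboxy-2-methylpropyl in place of the three-membered ring of 1-carboxycyclopropyl gives a 1.7-fold lower number from compound 3 to compound 4 (0.23 log units; within the scatter), so the ring and the open chain do not separate here. Carboxy in place of hydroxymethyl on the same branched chain, a direct acid-for-alcohol pair that the earlier compounds lacked, gives a 1.0-fold lower number from compound 2 to compound 4 (0.02 log units; within the scatter), and 1-carboxy-2-methylpropyl in place of 2-hydroxyethyl gives a 1.6-fold higher number from compound 1 to compound 4 (0.20 log units; within the scatter), so at this position neither change moves the number beyond the scatter. No measurement is available to explain these small steps.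

The compounds shown leave open whether an amine or a longer chain on the amide-type nitrogen would give a step beyond the scatter. They also leave open how the mirror-image form of 1-carboxy-2-methylpropyl would compare.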